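A few compounds are considered here, and "the series" means these few. Any claim that something is new, unique, unknown or untested is made for them only; others in the source may bear on it.

Compound 1 `Cc1cccc(CN2CCN(C(=O)CN[C@H]3CCN(S(=O)(=O)Cc4ccccc4)C3)CC2)c1`: 11300 nM
Compound 2 `O=C(CN[C@H]1CCN(S(=O)(=O)Cc2ccccc2)C1)N1CCN(Cc2ccccc2Cl)CC1`: 9000 nM
Compound 3 `O=C(CN[C@H]1CCN(S(=O)(=O)Cc2ccccc2)C1)N1CCN(Cc2cccc(F)c2)CC1`: 13200 nM

These three compounds share one core and differ only in the aryl group on a saturated chain carbon bound to an amine nitrogen in a ring. In a functional assay on K562 cells (Homo sapiens) for cytotoxicity, read by MTT assay, with a stated time of 48 h (a higher number here means a weaker inhibitor, a lower number a stronger inhibitor), compound 2 gives the lowest of the three numbers, yet the step of a 1.3-fold lower number from compound 1 to compound 2 (0.10 log units; within the scatter) and the step of a 1.5-fold higher number from compound 2 to compound 3 (0.17 log units; within the scatter) both lie within the scatter, so nothing separates the three compounds.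

Compound 4 `COc1cccc(CN2CCN(C(=O)CN[C@H]3CCN(S(=O)(=O)Cc4ccccc4)C3)CC2)c1` is the next member of this series. It differs from compound 2 in that (3-methoxyphenyl in place of 2-chlorophenyl on a saturated chain carbon bound to an amine nitrogen in a ring). Among the compounds with values here, the steps that bear on this change are the earlier swaps of the same aryl group: a 1.3-fold lower number from compound 1 to compound 2 (0.10 log units; within the scatter), a 1.2-fold higher number from compound 1 to compound 3 (0.07 log units; within the scatter) and a 1.5-fold higher number from compound 2 to compound 3 (0.17 log units; within the scatter), each within the scatter. On that basis no step beyond the scatter is expected in this assay in either direction. Compound 4 is therefore expected to give about 11000 nM, within a range of 5500 nM to 22000 nM. The expected step is a 1.2-fold higher number from compound 2 to compound 4 (0.09 log units; within the scatter).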

Compound 4, half-maximal inhibitory concentration: 60800 nM
The estimate for compound 4 lay 5.5-fold (0.74 log units) below the measured number; the measured number lies above the stated range.
By their numbers in this assay, from the lowest: compounds 2, 1 and 3 (each within the scatter of the next); then compound 4.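

The aryl group at this place is less interchangeable than the first three compounds suggested: in this assay, 3-methoxyphenyl makes compound 4 the weakest of the four, against 2-chlorophenyl (a 6.8-fold higher number from compound 2 to compound 4 (0.83 log units; beyond the scatter)). The other two steps are the more telling, since the group stays at the same numbered ring position and only the substituent changes: methoxy in place of methyl (a 5.4-fold higher number from compound 1 to compound 4 (0.73 log units; beyond the scatter)) and methoxy in place of fluoro (a 4.6-fold higher number from compound 3 to compound 4 (0.66 log units; beyond the scatter)). Nothing measured here explains why methoxy departs from the other groups.

As far as these compounds go, it remains open whether this loss belongs to methoxy alone or would also appear with a hydroxy, ethoxy or dimethylamino group in its place. Whether the same swap would give a step of this size on a different core is also unknown.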